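Swapping the aryl group: from compound 2 toward compound 4

The source may report more compounds than this note shows. Statements on the series, on what has been measured and on what is new or still open speak of the compounds shown alone.

Compound 1, `CC/C(=C(/c1ccc(/C=C/C(=O)O)cc1)c1cc2ccccc2[nH]1)c1ccccc1`: 108 nM
Compound 2, `CC/C(=C(/c1ccc(/C=C/C(=O)O)cc1)c1cc2ccccc2[nH]1)c1cccc(OC(F)(F)F)c1`: 282 nM
Compound 3, `CC/C(=C(/c1ccc(/C=C/C(=O)O)cc1)c1cc2ccccc2[nH]1)c1cccc(F)c1C#N`: 40 nM

In a functional assay on MCF7 cells (Homo sapiens) for inhibition (on this read-out higher numbers stand for weaker inhibition and lower numbers for stronger inhibition), compound 2 gives the highest number of the three measured, that is, the weakest inhibition. Compound 4, `CC/C(=C(/c1ccc(/C=C/C(=O)O)cc1)c1cc2ccccc2[nH]1)c1ccc(F)cc1Cl`, differs from compound 2 by 2-chloro-4-fluorophenyl in place of 3-(trifluoromethoxy)phenyl on a double-bonded chain carbon bound to a double-bonded chain carbon and a saturated chain carbon. Going by the values given here, two measured steps bear on this change: a 2.6-fold higher number from compound 1 to compound 2 (0.42 log units; beyond the scatter) shows that adding the trifluoromethoxy group weakened inhibition, and a 7.1-fold lower number from compound 2 to compound 3 (0.85 log units; beyond the scatter) shows that exchanging the same 3-(trifluoromethoxy)phenyl for a differently substituted phenyl strengthened it markedly. Removing the trifluoromethoxy group alone is expected to bring compound 4 back toward the level of compound 1 at 108 nM, and a second substituted phenyl is expected to land near or somewhat below that level. Compound 4 is therefore expected at 90 nM, a step of a 3.1-fold lower number from compound 2 to compound 4 (0.50 log units; beyond the scatter), within a range from 35 nM to 250 nM.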

Compound 4, half-maximal inhibitory concentration: 39 nM
The estimate for compound 4 lay 2.3-fold (0.36 log units) above the measured number; low and high end bracket the measured number.
By their numbers in this assay, from the lowest: compounds 4 and 3 (each within the scatter of the next); then compound 1; then compound 2.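

A nitrile is not needed for a gain at this position: compound 4 has none, yet a 2.8-fold lower number from compound 1 to compound 4 (0.44 log units; beyond the scatter) shows stronger inhibition than with the plain phenyl. The new ring also outperforms the 3-(trifluoromethoxy)phenyl ring, with a 7.2-fold lower number from compound 2 to compound 4 (0.86 log units; beyond the scatter) marking that step. Two differently substituted rings can therefore perform alike, as a 1.0-fold lower number from compound 3 to compound 4 (0.01 log units; within the scatter) places these compounds within the scatter of each other.

From the compounds shown here alone, whether the chlorine or the fluorine alone would give this gain remains open, as does the effect of an amine or a methoxy group on this ring. Nothing available here explains the differences between these rings.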